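Series notes: para substituent swap on the phenethyl imidazole core

The source may hold more compounds than are shown below. What is called first, only, known or untested is meant among the compounds shown, and "the series" means these compounds.

Measured compounds in a functional assay on HEK293 cells for agonist activity at Bombesin receptor subtype-3 (Mus musculus), read by luminescence and calcium flux, with a stated time of 10 min; on this read-out lower numbers stand for an effect already at smaller amounts and higher numbers for an effect only at larger amounts of compound:
compound 1 `c1ccc(-c2ccc(CCc3nc(CC4CCCC4)c[nH]3)cc2)nc1`: 103 nM
compound 2 `CCC(C)(C)Cc1c[nH]c(CCc2ccc(-c3csnn3)cc2)n1`: 109 nM
compound 3 `CCC(C)(C)Cc1c[nH]c(CCc2ccc(-c3cnccn3)cc2)n1`: 107 nM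

Compound 2 `CCC(C)(C)Cc1c[nH]c(CCc2ccc(-c3csnn3)cc2)n1` gives 109 nM in this assay, and the numbers of compound 1 and compound 3 lie within the scatter of it, so the three compounds are not separated on this read-out.

Compound 4 `CCC(C)(C)Cc1c[nH]c(CCc2ccc(N3CCCCC3)cc2)n1` is not yet measured. The change from compound 2 to compound 4 is piperidin-1-yl in place of 1,2,3-thiadiazol-4-yl on an aromatic carbon.

Within the data shown here, the only measured step at the same place is a 1.0-fold lower number from compound 2 to compound 3 (0.01 log units; within the scatter), an exchange of one aromatic ring for another. It gives no guide to the size of the step when a non-aromatic ring enters. Given that the one available step at this place produced no movement, the working expectation for compound 4 is a number near that of compound 2, estimated as a 1.2-fold higher number from compound 2 to compound 4 (0.08 log units; within the scatter), with a wider band to reflect the untested nature of the change.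

Compound 4 is therefore estimated at 130 nM in this assay, with a range from 40 nM to 450 nM.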

Compound 4, half-maximal effective concentration: 133 nM
For compound 4 the middle estimate is 1.0-fold (0.01 log units) below the measured one; the range from low to high includes it.
By their numbers in this assay, from the lowest: compounds 1, 3, 2 and 4 (each within the scatter of the next).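

In this assay the steps of a 1.2-fold higher number from compound 2 to compound 4 (0.09 log units; within the scatter) and a 1.2-fold higher number from compound 3 to compound 4 (0.09 log units; within the scatter) bring the only non-aromatic ring shown at this place, on an aromatic carbon and para to a large group. The number therefore does not separate piperidin-1-yl from the two aromatic rings, so an aromatic ring at this place is not required for a value in this range, and going from 3 hydrogen-bond acceptors in 1,2,3-thiadiazol-4-yl to 1 hydrogen-bond acceptor in piperidin-1-yl leaves the compounds unseparated as well. No measurement here offers an explanation for this lack of separation.

Every group shown at this place is a ring, so open-chain groups such as a carboxylic acid, a primary amine or a methoxy group remain open. Whether any substituent here can move the number beyond the scatter also remains unanswered.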